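The source may hold more compounds than are shown below. What is called first, only, known or untested is meant among the compounds shown, and "the series" means these compounds.

Measured compounds in a functional assay on MKN-45 cells (Homo sapiens) for antiproliferative activity, read by MTT assay, with a stated time of 72 h, tested at 10 uM; on this read-out higher numbers stand for more inhibition at the one concentration tested (going by the name of the read-out) and lower numbers for less inhibition:
Compound 1 `CCCC(=O)Nc1cc(Oc2ccc(Nc3nccc4[nH]cc(-c5ccc(F)cc5)c(=O)c34)cc2F)ccn1`, 64.6%
Compound 2 `CC(C)(O)Cn1cc(-c2ccc(F)cc2)c(=O)c2c(Nc3ccc(Oc4ccnc(NC(=O)C5CC5)c4)c(F)c3)nccc21`, 44.3%
Compound 3 `CC(C)(C)C(=O)Nc1cc(Oc2ccc(Nc3nccc4[nH]cc(-c5ccc(F)cc5)c(=O)c34)cc2F)ccn1`, 62.5%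

Compound 1 gives the largest of the three numbers, yet compound 3 lies within the scatter of it, while compound 2 sits beyond the scatter below it. Among the measured compounds shown here, the one single-point step measured, a number 2.1 percentage points lower from compound 1 to compound 3 (within the scatter), shows that exchanging one acyl group for another on the amide left the read-out unchanged. Compound 4 `Nc1nccc(Oc2ccc(Nc3nccc4[nH]cc(-c5ccc(F)cc5)c(=O)c34)cc2F)c1Cl` differs from compound 1 by 2-amino-3-chloropyridin-4-yl in place of 2-((propylcarbonyl)amino)pyridin-4-yl on an oxygen on an aromatic ring. For the measured compounds named here, no measured step covers the removal of the acyl group together with the entry of chlorine, so the direction is uncertain; compound 2 shows the read-out can drop when the core is altered elsewhere. Compound 4 is therefore expected to give 50%, between 30% and 70%, a step of a number 14.6 percentage points lower from compound 1 to compound 4 (beyond the scatter) that is estimated, not measured.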

Compound 4, a percentage reported as inhibition, at one concentration (the size of the read-out at that concentration, not a potency): 85.7%
Estimate against measurement, compound 4: 35.7 percentage points below; measured number outside the range, above it.
By their numbers in this assay, from the lowest: compound 2; then compounds 3 and 1 (each within the scatter of the next); then compound 4.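

In this assay, replacing 2-((propylcarbonyl)amino)pyridin-4-yl with 2-amino-3-chloropyridin-4-yl on the oxygen gave a number 21.1 percentage points higher from compound 1 to compound 4 (beyond the scatter) and so changed the read-out, which a number 2.1 percentage points lower from compound 1 to compound 3 (within the scatter) had not done. On this core, the acyl group is therefore not needed for inhibition at the one concentration tested. Nothing available explains the rise. The compounds shown leave open how much of the step belongs to the chlorine and how much to the loss of the acyl group. They also leave open whether a fluorine or a methyl in the chlorine's place would read the same.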